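The source may report more compounds than this note shows. Statements on the series, on what has been measured and on what is new or still open speak of the compounds shown alone.

Measured compounds in a functional assay on NCI-H460 cells (Homo sapiens) for inhibition, read by sulforhodamine B assay, with a stated time of 48 h; on this read-out higher numbers stand for weaker inhibition of growth and lower numbers for stronger inhibition of growth:
compound 1 `O=C1C=COC(/C=C/c2ccccc2)C1`: 82.4 uM
compound 2 `COc1ccc(/C=C/C2CC(=O)C=CO2)cc1`: 149 uM
compound 3 `COc1ccc(/C=C/C2CC=CC(=O)N2)cc1`: > 1090 uM

The value of compound 3 is a limit of the assay, (the limit of > 1090 uM in this assay, at which 1 of the 3 values shown sits). Compounds 1 and 2 share one core; compound 3 has another, and the difference between the two cores is not broken down here. From compound 1 to compound 2 the change is methoxy in place of hydrogen on an aromatic carbon, which gave a 1.8-fold higher number from compound 1 to compound 2 (0.26 log units; within the scatter). Compound 4 `COc1ccc(/C=C/C2CC=CC(=O)N2)c(OC)c1` has not yet been measured; it arises from compound 3 by methoxy in place of hydrogen on an aromatic carbon. This is the same kind of change, but the place differs: para to a group of 9 heavy atoms in the first case, ortho to a group of 9 heavy atoms and meta to a methoxy group in the second. The earlier step lay within the scatter. A step of similar size is therefore expected, a step that the limit leaves unreadable from compound 3 to compound 4. Compound 4 is expected to give 1500 uM, probably again as a limit only, between 700 uM and 5000 uM.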

Compound 4, concentration for growth inhibition (reported as GI): > 964 uM
Compound 4 gave a limit, no number; the forecaster's own chance of this, stated with the estimate: 85%; the middle value does not contradict the limit.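

Compound 3 and compound 4 both stand only as limits of the assay, not as numbers, and the step between them cannot be read. The compounds shown leave open whether methoxy in place of hydrogen on an aromatic carbon alters growth inhibition on the core of compound 3.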